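Moving a Chlorine on the Aryl Group of Compound 3

The source may report more compounds than this note shows. Statements on the series, on what has been measured and on what is new or still open speak of the compounds shown alone.

In an ADME assay (Rattus norvegicus) for metabolic stability (a lower number here means that less of the compound is left, a higher number that more of the compound is left), compound 3 `Clc1nc(N[C@@H]2C[C@H]3CC[C@@H]2C3)c2cc(-c3ccc(Cl)c(Cl)c3)ccc2n1` gives 59%, the highest of the three numbers seen so far. Compound 1 `Cc1nc(N[C@@H]2C[C@H]3CC[C@@H]2C3)c2cc(-c3cc(Cl)cc(Cl)c3)ccc2n1` gives 37% and compound 2 `Fc1ccc(-c2ccc3nc(Cl)nc(N[C@@H]4C[C@H]5CC[C@@H]4C5)c3c2)cc1` gives 36%, both lying beyond the scatter below compound 3. Going by the values given here, the single one-place step measured, a number 23 percentage points higher from compound 2 to compound 3 (beyond the scatter), shows that the aryl group attached to the shared core can shift the read-out considerably. Compound 4 `Clc1cc(Cl)cc(-c2ccc3nc(Cl)nc(N[C@@H]4C[C@H]5CC[C@@H]4C5)c3c2)c1` alters that group once more: 3,5-dichlorophenyl in place of 3,4-dichlorophenyl on an aromatic carbon. Among the compounds with values here, no measured step covers this move of a chlorine by itself. Compound 1 also carries a 3,5-dichlorophenyl, but it differs from compound 3 in a second place too, so its lower number is only a hint that the new arrangement may lose some ground. The expected step is therefore a modest fall, a number 12 percentage points lower from compound 3 to compound 4 (beyond the scatter). Compound 4 is estimated at 47%, most likely between 30% and 65%.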

Compound 4, percent of the compound remaining: 76%
Beside the measured number, compound 4's estimate is 29 percentage points below it; measured number outside the range, above it.
By their numbers in this assay, from the lowest: compounds 2 and 1 (each within the scatter of the next); then compound 3; then compound 4.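

Moving one chlorine, with the atoms otherwise unchanged, gives a number 17 percentage points higher from compound 3 to compound 4 (beyond the scatter) in this assay, so the arrangement of the two chlorines on this aryl group matters, not only their presence. Against the 4-fluorophenyl, the 3,5-dichlorophenyl gives a number 40 percentage points higher from compound 2 to compound 4 (beyond the scatter) and so stands well clear of it on the same core. With the 3,5-dichlorophenyl held constant, chloro in place of methyl gives a number 39 percentage points higher from compound 1 to compound 4 (beyond the scatter), which shows that this aryl group does not by itself bring a low number and that the second place on the core also counts heavily. Going by these compounds, whether trifluoromethyl groups or methoxy groups in the place of these chlorines would hold the number, or an amine in place of the chloro on the core, stays open. Nothing here bears on why these changes move the number.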